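Swapping methylamino for methyl in an inactive series

The compounds below may be only part of what the source reports. "The series", "measured", "known", "first", "only" and "open" are said of these compounds alone.

Measured in a functional assay on HCT-116 cells (Homo sapiens), read by MTT assay, with a stated time of 72 h (on this read-out higher numbers stand for weaker inhibition and lower numbers for stronger inhibition), each value a limit of the assay:
- compound 1 `CNc1ncnc2c1c(-c1cccs1)cn2[C@@H]1O[C@H](CO)[C@@H](O)[C@H]1O`: > 20000 nM
- compound 2 `CNc1ncnc2c1c(-c1cc3ccccc3o1)cn2[C@@H]1O[C@H](CO)[C@@H](O)[C@H]1O`: > 20000 nM
- compound 3 `C#Cc1cn([C@@H]2O[C@H](CO)[C@@H](O)[C@H]2O)c2ncnc(NC)c12`: > 20000 nM

In this assay compound 2 gives > 20000 nM, which is a limit and not a number. It has no rank among the measured compounds, since all three share (the limit of > 20000 nM in this assay, at which 3 of the 3 values shown sit).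

The next compound is compound 4 `Cc1ncnc2c1c(-c1cc3ccccc3o1)cn2[C@@H]1O[C@H](CO)[C@@H](O)[C@H]1O`. It keeps the 1-benzofuran-2-yl group of compound 2 but carries methyl in place of methylamino on an aromatic carbon.

The measured steps offer little guidance. Two of them touch compound 2: a step that the two limits leave unreadable from compound 1 to compound 2 and a step that the two limits leave unreadable from compound 2 to compound 3. The third is a step that the two limits leave unreadable from compound 1 to compound 3. All three exchange the group on the other aromatic carbon, and none has a readable size. Within the data shown here, all three compounds also carry methylamino, so no measured step shows what removing it does.

With nothing pointing towards a change, the safest expectation is that compound 4 stays near the limit, although a measurable number cannot be ruled out. The expected step is an at least 1.3-fold lower number from compound 2 to compound 4 (0.12 log units; that floor lies within the scatter), and it has no firm direction. For compound 4 the estimated value is 15000 nM, with an expected range of 4000 nM to 30000 nM.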

Compound 4, half-maximal inhibitory concentration: > 20000 nM
Compound 4: no number, only a limit; the forecaster's own chance of this, stated with the estimate: 65%; middle value at least 1.3-fold (0.12 log units) from the limit.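

Compound 4 gives > 20000 nM, which is a limit and not a number. Compound 2 also sits at a limit, so the exchange of methylamino for methyl between compound 2 and compound 4 cannot be read. The compounds shown leave open whether any of these changes alters activity, since no measurable value separates them: the limit of > 20000 nM in this assay, at which 4 of the 4 values shown sit.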